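Phenyl to Methyl Across Two Fused Cores

The source may hold more compounds than are shown below. What is called first, only, known or untested is meant among the compounds shown, and "the series" means these compounds.

Three compounds were measured in an assay on isolated protein for inhibition of ribosomal protein S6 kinase alpha-1 (Homo sapiens), read by mobility shift assay, tested at 30 uM; a higher number here means more inhibition at the concentration tested (going by the name of the read-out), a lower number less inhibition. Compound 1 `Cc1cc2nn(-c3ccccc3)c(N)c2c(=O)[nH]1` gives -11%, compound 2 `Nc1c2c(=O)[nH]c(-c3ccccc3)cc2nn1-c1ccccc1` gives 38%, and compound 3 `Cc1cc2nc(-c3ccccc3)nc(N)c2c(=O)[nH]1` gives 14%. One change connects the first two, (methyl in place of phenyl on an aromatic carbon), and it made a number 49 percentage points lower from compound 2 to compound 1 (beyond the scatter). How the cores of compound 2 and compound 3 differ is not broken down here. Compound 4 `Cc1nc(N)c2c(=O)[nH]c(C)cc2n1` has not yet been measured; it carries the same kind of change, (methyl in place of phenyl on an aromatic carbon), though here the place is on a six-membered aromatic ring with 2 nitrogen, between two ring nitrogen atoms and meta to an amino group, whereas in the earlier pair it was on a six-membered aromatic ring with 1 nitrogen, next to the ring nitrogen. Within the data shown here, for compound 4 the expected step is a number 26 percentage points lower from compound 3 to compound 4 (beyond the scatter), resting on a number 49 percentage points lower from compound 2 to compound 1 (beyond the scatter) as the only earlier instance of this change. Compound 4 is therefore estimated at -12%, between -32% and 10%.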

Compound 4, a percentage reported as inhibition, at one concentration (the size of the read-out at that concentration, not a potency): -23%
Beside the measured number, compound 4's estimate is 11 percentage points above it; the range from low to high includes it.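

In this assay, methyl in place of phenyl on an aromatic carbon again cost inhibition, with a number 37 percentage points lower from compound 3 to compound 4 (beyond the scatter). Among these compounds, the change therefore carried from one core to the other with no difference between the two steps that stands out from the scatter: the same change on two cores in this assay, a number 49 percentage points lower (beyond the scatter) from compound 2 to compound 1 and a number 37 percentage points lower (beyond the scatter) from compound 3 to compound 4, 12 percentage points apart, within the scatter of two such steps This rests on only two pairs, each read at a single concentration, so it shows neither that the same step would hold on any further core nor why phenyl gives the higher reading.

On these data alone, what an amine, a carboxylic acid or a longer chain at that aromatic carbon would give remains open. So does whether a substituted phenyl there would match or exceed the unsubstituted one.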